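The source may hold more compounds than are shown below. What is called first, only, known or untested is meant among the compounds shown, and "the series" means these compounds.

Measured so far in a functional assay on MDA-MB-435 cells (Homo sapiens) for inhibition, read by sulforhodamine B assay, with a stated time of 48 h (on this read-out lower numbers stand for stronger inhibition of growth and higher numbers for weaker inhibition of growth), for this series:
- compound 1 `O=C(Nc1cccc(-n2cc(-c3ccncc3)c(-c3ccc(Cl)c(O)c3)n2)c1)Nc1cccc(C(F)(F)F)c1` at 1490 nM
- compound 2 `COc1cc(-c2nn(-c3cccc(NC(=O)c4cccc(C(F)(F)F)c4)c3)cc2-c2ccncc2)ccc1Cl` at 705 nM
- compound 3 `O=C(Nc1cccc(-n2cc(-c3ccncc3)c(-c3ccc(Cl)c(O)c3)n2)c1)Nc1ccc(Cl)c(Cl)c1` at 1100 nM

Compound 2 at 705 nM lies within the scatter of compound 3 at 1100 nM. Compound 1 gives 1490 nM, and the gap between it and compound 2 lies beyond the scatter, with compound 2 on the low side. Compound 2 therefore shares the low end of these numbers with compound 3.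

Compound 4 `COc1cc(-c2nn(-c3cccc(NC(=O)c4ccc(Cl)c(C(F)(F)F)c4)c3)cc2-c2ccncc2)ccc1Cl` differs from compound 2 in one place (chloro in place of hydrogen on an aromatic carbon). It has chloro in place of hydrogen on an aromatic carbon, ortho to a trifluoromethyl group and para to a large group, so 3-(trifluoromethyl)phenyl becomes 4-chloro-3-(trifluoromethyl)phenyl.

Among the measured compounds shown here, only one measured step bears on this, and only loosely: a 1.4-fold lower number from compound 1 to compound 3 (0.13 log units; within the scatter) stays within the scatter. In that step 3,4-dichlorophenyl replaces 3-(trifluoromethyl)phenyl, so a chloro enters while the trifluoromethyl group leaves, and the pair also differs from compound 2 elsewhere in the molecule. For the measured compounds named here, no measured pair adds a chloro to compound 2 itself.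

No change beyond the scatter is therefore expected in this assay from this replacement. The expected step is a 1.1-fold lower number from compound 2 to compound 4 (0.06 log units; within the scatter) and it rests on thin evidence. Compound 4 is estimated at 620 nM with an expected range of 270 nM to 1400 nM on this read-out.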

Compound 4, concentration for 50% growth inhibition: 664 nM
Estimate against measurement, compound 4: 1.1-fold (0.03 log units) below; the range from low to high includes it.
By their numbers in this assay, from the lowest: compounds 4, 2, 3 and 1 (each within the scatter of the next, the first and the last beyond it).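

In this assay, among the compounds shown here, chloro in place of hydrogen on the 3-(trifluoromethyl)phenyl ring gives a 1.1-fold lower number from compound 2 to compound 4 (0.03 log units; within the scatter) and so provides the first reading of this addition with the trifluoromethyl group kept. The earlier step, a 1.4-fold lower number from compound 1 to compound 3 (0.13 log units; within the scatter), had a chloro entering while the trifluoromethyl group left, so it could not show the effect of the chloro alone. The new pair shows that this aromatic carbon, ortho to a trifluoromethyl group and para to a large group, carries a chloro with no change beyond the scatter, but nothing available explains that outcome.

Still open, on these data alone, is whether this tolerance is particular to chloro or extends to other groups on the same carbon, such as an amine, a carboxylic acid or a longer chain, each read as a single change from compound 2. Also open, as far as these compounds go, is whether the same chloro addition gives a similar reading on the core of compound 1 or compound 3, where the linking group and the substituents on the chlorophenyl ring differ from those of compound 2.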